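From 3-fluorophenyl to 2-chlorophenyl on a shared core

The compounds below may be only part of what the source reports. "The series", "measured", "known", "first", "only" and "open" are said of these compounds alone.

In an ADME assay on HUVEC cells (Homo sapiens) for inhibition, read by CCK-8 assay, with a stated time of 24 h, in the presence of a further agent that is not named here (a higher number here means a weaker inhibitor, a lower number a stronger inhibitor), compound 1 `Cc1cccc(-n2cc(-c3ccc(/C=C4\C(=O)Nc5ccc(F)cc54)cc3)nn2)c1` gives 9880 nM and compound 2 `Cc1ccc(-n2cc(-c3ccc(/C=C4\C(=O)Nc5ccc(F)cc54)cc3)nn2)cc1` gives 13800 nM and compound 3 `O=C1Nc2ccc(F)cc2/C1=C/c1ccc(-c2cn(-c3cccc(F)c3)nn2)cc1` gives 17300 nM as its reading, so compound 3 stands within the scatter of both others. Compound 4 `O=C1Nc2ccc(F)cc2/C1=C/c1ccc(-c2cn(-c3ccccc3Cl)nn2)cc1` differs from compound 3 by 2-chlorophenyl in place of 3-fluorophenyl on an aromatic nitrogen with 2-chlorophenyl in place of 3-fluorophenyl on an aromatic nitrogen. Three measured steps change the phenyl group on that nitrogen: a 1.4-fold higher number from compound 1 to compound 2 (0.15 log units; within the scatter) and a 1.8-fold higher number from compound 1 to compound 3 (0.24 log units; within the scatter) and a 1.3-fold higher number from compound 2 to compound 3 (0.10 log units; within the scatter) as well. None of them tests a 2-chlorophenyl group. No change beyond the scatter is therefore expected in this assay and the expected step is a 1.2-fold lower number from compound 3 to compound 4 (0.09 log units; within the scatter) in size. Compound 4 is estimated at 14000 nM with an expected range from 6000 nM to 32000 nM in this estimate.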

Compound 4, half-maximal inhibitory concentration: 18200 nM
For compound 4 the middle estimate is 1.3-fold (0.11 log units) below the measured one, and the stated range covers the measured number.
By their numbers in this assay, from the lowest: compounds 1, 2, 3 and 4 (each within the scatter of the next).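

In this assay, the 2-chlorophenyl group on the aromatic nitrogen does not separate from the three other substituted phenyl groups, with a 1.1-fold higher number from compound 3 to compound 4 (0.02 log units; within the scatter), a 1.3-fold higher number from compound 2 to compound 4 (0.12 log units; within the scatter) and a 1.8-fold higher number from compound 1 to compound 4 (0.27 log units; within the scatter). All four groups shown at this position therefore give readings that cannot be told apart, and this now holds for a chlorine-bearing phenyl group as well. Nothing measured here explains why the readings stay so close. It remains open whether a plain phenyl group would also fall among these readings. The same question stands for a phenyl group carrying an amine or a carboxylic acid, which might move the number beyond the scatter.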